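The source may hold more compounds than are shown below. What is called first, only, known or untested is meant among the compounds shown, and "the series" means these compounds.

Series notes

- compound 1 `Cn1ncc(Cl)c1-c1cc(C(=O)N[C@@H]2CN[C@H](CCO)C[C@H]2c2ccc(Cl)c(Cl)c2)oc1Cl`: 340 nM
- compound 2 `COCC[C@@H]1C[C@@H](c2ccc(Cl)c(Cl)c2)[C@H](NC(=O)c2cc(-c3c(Cl)cnn3C)c(Cl)o2)CN1`: 470 nM
- compound 3 `Cn1ncc(Cl)c1-c1cc(C(=O)N[C@@H]2CN[C@H](CC(=O)NC3CCC3)C[C@H]2c2ccc(Cl)c(Cl)c2)oc1Cl`: not yet measured

For the measured compounds named here, in a functional assay on HCT-116 cells (Homo sapiens) for antiproliferative activity, read by sulforhodamine B assay, with a stated time of 72 h (on this read-out higher numbers stand for weaker inhibition and lower numbers for stronger inhibition), compound 2 gives 470 nM, which lies within the scatter of compound 1, its only neighbour on the numbers so far.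

The next structure, compound 3, carries cyclobutylcarbamoyl in place of methoxymethyl on a saturated chain carbon bound to a saturated ring carbon. In words, this is cyclobutylcarbamoyl in place of methoxymethyl on a saturated chain carbon bound to a saturated ring carbon. The shared core is untouched.

Going by the values given here, only one measured step bears on this change: a 1.4-fold higher number from compound 1 to compound 2 (0.14 log units; within the scatter). It is methyl in place of hydrogen on an oxygen, within the same side chain, and it stays within the scatter. Among the compounds with values here, that step is a much smaller edit than the present one, and no measured compound carries an amide in this chain, so the evidence is thin. No shift beyond the scatter is expected in this assay, and no direction can be argued from two compounds. The expected step is a 1.1-fold higher number from compound 2 to compound 3 (0.03 log units; within the scatter), with wide uncertainty on either side.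

For compound 3 the estimated value is 500 nM, with an expected range of 150 nM to 1600 nM.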

Compound 3, half-maximal inhibitory concentration: 430 nM
For compound 3 the middle estimate is 1.2-fold (0.07 log units) above the measured one; the range from low to high includes it.
By their numbers in this assay, from the lowest: compounds 1, 3 and 2 (each within the scatter of the next).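

In this assay, cyclobutylcarbamoyl in place of methoxymethyl on a saturated chain carbon bound to a saturated ring carbon gives a 1.1-fold lower number from compound 2 to compound 3 (0.04 log units; within the scatter), and cyclobutylcarbamoyl in place of hydroxymethyl at the same place gives a 1.3-fold higher number from compound 1 to compound 3 (0.10 log units; within the scatter), so neither step leaves the scatter. The earlier step covered only a methyl on the side-chain oxygen, whereas these two show that this position accepts a larger group, with a four-membered carbon ring and an amide hydrogen, without a step beyond the scatter in this read-out. No evidence is at hand on why these three side chains read alike.

As far as these compounds go, whether the same holds for a primary amine or a carboxylic acid at the end of this chain, or for a longer chain, remains open. Also open, from the compounds shown here alone, is whether a primary carboxamide or a tertiary amide such as dimethylcarbamoyl would read like cyclobutylcarbamoyl, which would show whether the cyclobutyl ring or the amide hydrogen has any bearing on the values here.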